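This account rests on a few compounds, and the source may have more. Where it says the series, first, only, none or still open, it means among the compounds named here.

Measured so far in a functional assay on ECa-109 cells for inhibition, with ECa-109 cell line (Homo sapiens) as the target, read by sulforhodamine B assay; on this read-out higher numbers stand for weaker inhibition and lower numbers for stronger inhibition:
- compound 1 `O=C1C(N2CCCCC2)=CC(=O)c2c1nc1n2[C@H]2OC[C@@H](O)[C@H]2OC1` gives > 8000 nM
- compound 2 `COc1ccc(NC2=CC(=O)c3nc4n(c3C2=O)[C@H]2OC[C@@H](O)[C@H]2OC4)cc1` gives > 4000 nM

Neither of these is a true number. For compound 1 the figure is a limit of the assay, (the limit of > 8000 nM in this assay, at which 1 of the 2 values shown sits). For compound 2 the figure is also a limit, (the limit of > 4000 nM in this assay, at which 1 of the 2 values shown sits). For the measured compounds named here, compound 1 therefore stands at the weak edge of what this assay can report, and since both measured compounds sit at limits, the two values show no order between them and no step between measured compounds can be drawn.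

Compound 3 `O=C1C(NCc2ccccc2)=CC(=O)c2c1nc1n2[C@H]2OC[C@@H](O)[C@H]2OC1` differs from compound 1 in one place: benzylamino in place of piperidin-1-yl on a double-bonded ring carbon. Going by the values given here, there is no measured step to gauge what such a change does here. The expected step that the limit leaves unreadable from compound 1 to compound 3 is therefore none beyond the scatter, with the weak inhibition of compound 1 carried over. Compound 3 is estimated at 9000 nM, in a range from 2500 nM to 30000 nM, and another limit rather than a number is expected to be the most likely outcome.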

Compound 3, half-maximal inhibitory concentration: > 8000 nM
Compound 3 gave a limit, no number; the forecaster's own chance of this, stated with the estimate: 70%; the middle value is on the limit's open side.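

Compound 1 and compound 3 both end at a limit of the assay rather than a true number, so no step can be read for benzylamino in place of piperidin-1-yl. The compounds shown leave open how strongly any of them inhibits these cells, and whether this swap changes inhibition at all.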